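Cytotoxicity on colon cancer cells: phenyl substituent swap

A few compounds are considered here, and "the series" means these few. Any claim that something is new, unique, unknown or untested is made for them only; others in the source may bear on it.

Compound 1 `C=CC(=O)Nc1cc(Nc2ncc3ncn(-c4ccccc4)c3n2)c(OC)cc1N(C)CCN(C)C` in an ADME assay on HT-29 cells (Homo sapiens) for cytotoxicity, read by MTT assay, with a stated time of 72 h; on this read-out higher numbers stand for weaker inhibition and lower numbers for stronger inhibition: 8080 nM
Compound 2 `C=CC(=O)Nc1cc(Nc2ncc3ncn(-c4ccc(CC)cc4)c3n2)c(OC)cc1N(C)CCN(C)C`: 8180 nM
Compound 3 `C=CC(=O)Nc1cc(Nc2ncc3ncn(-c4ccc(Cl)cc4)c3n2)c(OC)cc1N(C)CCN(C)C`: 7690 nM

Compound 3 gives the lowest of the three numbers in this assay, but its neighbours sit within the scatter, so no ordering is claimed. Compound 4 `C=CC(=O)Nc1cc(Nc2ncc3ncn(-c4ccccc4F)c3n2)c(OC)cc1N(C)CCN(C)C` differs from compound 3 by 2-fluorophenyl in place of 4-chlorophenyl on an aromatic nitrogen. The two steps that bear on this replace hydrogen on that phenyl ring: a 1.1-fold lower number from compound 1 to compound 3 (0.02 log units; within the scatter) and a 1.1-fold lower number from compound 2 to compound 3 (0.03 log units; within the scatter), both within the scatter. Changing the substituent on this phenyl ring has so far moved nothing beyond the scatter, so compound 4 is expected to show no step beyond the scatter, a 1.0-fold higher number from compound 3 to compound 4 (0.01 log units; within the scatter). Compound 4 is estimated at 7900 nM, within a range from 4000 nM to 16000 nM.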

Compound 4, half-maximal inhibitory concentration: 9750 nM
Beside the measured number, compound 4's estimate is 1.2-fold (0.09 log units) below it; low and high end bracket the measured number.
By their numbers in this assay, from the lowest: compounds 3, 1, 2 and 4 (each within the scatter of the next).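

Compound 4 puts a fluoro group on the phenyl ring in place of the 4-chloro and 4-ethyl groups, so both the substituent and its place on the ring have now changed. Even so, in this assay the three new steps, a 1.3-fold higher number from compound 3 to compound 4 (0.10 log units; within the scatter) and a 1.2-fold higher number from compound 2 to compound 4 (0.08 log units; within the scatter) and a 1.2-fold higher number from compound 1 to compound 4 (0.08 log units; within the scatter), all stay within the scatter, leaving all four compounds indistinguishable on this read-out. No supporting evidence accompanies this result to explain it.

Still open, as far as these compounds go, is whether an amine or a carboxylic acid on this phenyl ring would shift the number beyond the scatter, and whether a longer chain in place of the whole ring on the aromatic nitrogen would do so.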